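The source may hold more compounds than are shown below. What is called first, only, known or untested is meant among the compounds shown, and "the series" means these compounds.

Measured in a functional assay on MCF7 cells (Homo sapiens) for antiproliferative activity, read by sulforhodamine B assay, with a stated time of 48 h; a higher number here means a weaker inhibitor, a lower number a stronger inhibitor:
- compound 1 `COc1ccccc1OS(=O)(=O)c1ccc(N2CCN(C)C2=O)cc1`: 26000 nM
- compound 2 `CN1CCN(c2ccc(S(=O)(=O)Oc3cccc(Cl)c3)cc2)C1=O`: 2200 nM

Compound 2 holds the lower of the two numbers, at 2200 nM. Going by the values given here, the only measured step, a 12-fold lower number from compound 1 to compound 2 (1.07 log units; beyond the scatter), is large and comes with 3-chlorophenyl in place of 2-methoxyphenyl on an oxygen.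

Compound 3 `COc1ccc(OS(=O)(=O)c2ccc(N3CCN(C)C3=O)cc2)cc1` is not yet measured. Its change from compound 2 is 4-methoxyphenyl in place of 3-chlorophenyl on an oxygen. The 3-chlorophenyl therefore leaves, and a methoxyphenyl returns in a different form from the 2-methoxyphenyl of compound 1. Among the compounds with values here, no measured compound carries the 4-methoxyphenyl, so the single step offers only partial guidance.

Compound 1, with its methoxyphenyl, gives 26000 nM, which points towards a higher number in this assay. The step is expected to be smaller than the measured one, since the two methoxyphenyl groups need not behave alike. The estimated move is a 3.6-fold higher number from compound 2 to compound 3 (0.56 log units; beyond the scatter). For compound 3 the expected value is 8000 nM, with an estimated range from 2000 nM to 30000 nM.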

Compound 3, half-maximal inhibitory concentration: 95000 nM
Compound 3: middle estimate off by 12-fold (1.07 log units), on the low side; measured number above the stated range.
By their numbers in this assay, from the lowest: compound 2; then compound 1; then compound 3.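

In this assay, the group on the oxygen whose other neighbour is the sulfonyl sulfur now spans a wider range: a 43-fold higher number from compound 2 to compound 3 (1.64 log units; beyond the scatter) is the largest step in the series and exceeds the earlier step from 2-methoxyphenyl to 3-chlorophenyl. The two methoxyphenyl groups also do not read alike, with a 3.7-fold higher number from compound 1 to compound 3 (0.56 log units; beyond the scatter) separating 4-methoxyphenyl from 2-methoxyphenyl, so the name methoxyphenyl alone does not fix the number, although both methoxyphenyl compounds stand above compound 2 and none of the three compounds goes against that order. No supporting data accompany these values, so the size of the steps and the gap between the two methoxyphenyl groups stay without an explanation.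

On these data alone, the three groups differ in both substituent and placement, so it remains open whether the low number of compound 2 follows the chlorine itself or its placement as 3-chlorophenyl. As far as these compounds go, a 3-methoxyphenyl, a 4-chlorophenyl and an unsubstituted phenyl on the same oxygen would separate these two readings, and whether the order holds on any core other than the shared one also remains open.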